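Methoxy in Place of Pyrazolyl: Expected Loss of Agonism

The source may hold more compounds than are shown below. What is called first, only, known or untested is meant among the compounds shown, and "the series" means these compounds.

Compound 1, `CS(=O)(=O)Nc1cccc2c1CCC2c1ncc[nH]1`, > 10000 nM (a limit); compound 2, `Cn1cc(-c2cccc3c2CCC3c2ncc[nH]2)cn1`, > 10000 nM (a limit); compound 3, `c1cc(-c2ccn[nH]2)c2c(c1)C(c1ncc[nH]1)CC2`, 600 nM.

For the measured compounds named here, in a functional assay on CHO cells for agonist activity at Alpha-1B adrenergic receptor (Homo sapiens), read by FLIPR and calcium flux (on this read-out higher numbers stand for an effect only at larger amounts of compound and lower numbers for an effect already at smaller amounts), compound 3 gives 600 nM, the only number among the three values shown. Compound 1 reaches only the limit of > 10000 nM. Compound 2 likewise reaches only the limit of > 10000 nM. The shared core therefore carries measurable agonism only with the 1H-pyrazol-5-yl, as the steps of an at least 16-fold lower number from compound 1 to compound 3 (1.22 log units; beyond the scatter) and an at least 16-fold lower number from compound 2 to compound 3 (1.22 log units; beyond the scatter) show, both resting on (the limit of > 10000 nM in this assay, at which 2 of the 3 values shown sit).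

Compound 4, `COc1cccc2c1CCC2c1ncc[nH]1`, differs from compound 3 in one place: methoxy in place of 1H-pyrazol-5-yl on an aromatic carbon. Both measured steps that bear on this position show that replacing the 1H-pyrazol-5-yl by another group costs at least the large step seen from compound 1 and from compound 2. The expectation for compound 4 is a comparable loss, with a 13-fold higher number from compound 3 to compound 4 (1.12 log units; beyond the scatter) in this assay. Compound 4 is estimated at 8000 nM, within 2000 nM to 30000 nM, and may well reach only the limit.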

Compound 4, half-maximal effective concentration: > 10000 nM
Compound 4 ended at the assay's limit; the forecaster's own chance of this, stated with the estimate: 55%; middle value at least 1.2-fold (0.09 log units) from the limit.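

In this assay, the change to methoxy brings an at least 16-fold higher number from compound 3 to compound 4 (1.22 log units; beyond the scatter), and this small group, with 2 heavy atoms and no ring, fares no better than the larger replacements. Among the four groups shown on this aromatic carbon, only the 1H-pyrazol-5-yl of compound 3 gives a number, while methoxy joins methanesulfonamido and 1-methyl-1H-pyrazol-4-yl at the limit. The steps among compound 1, compound 2 and compound 4 cannot be read, because all three compounds stand at the same limit: the limit of > 10000 nM in this assay, at which 3 of the 4 values shown sit.

The compounds shown leave open whether anything other than the 1H-pyrazol-5-yl can carry agonism here, for example a 1H-pyrazol-4-yl, a 1-methyl-1H-pyrazol-5-yl or a simple amine. They also leave open how far each of the three groups at the limit lies from it.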